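A few compounds are considered here, and "the series" means these few. Any claim that something is new, unique, unknown or untested is made for them only; others in the source may bear on it.

Measured compounds:
compound 1 `CCOc1ccc2sc(S(C)(=O)=O)nc2c1S(=O)(=O)NC(C)(C)C` gives 600 nM in a functional assay on HeLa cells (Homo sapiens) for inhibition, read by sulforhodamine B assay, with a stated time of 48 h; a higher number here means a weaker inhibitor of growth, a lower number a stronger inhibitor of growth
compound 2 `CCOc1ccc2sc(S(C)(=O)=O)nc2c1S(=O)(=O)Nc1ccc(Br)cc1` gives 6800 nM in this assay

Among the compounds with values here, compound 2 holds the highest of the two numbers; its nearest neighbour is compound 1, and the measured step from one to the other, an 11-fold higher number from compound 1 to compound 2 (1.05 log units; beyond the scatter), is the only step in hand. That step exchanged the group on the sulfonamide nitrogen for a 4-bromophenyl ring, and it weakened growth inhibition by a large margin.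

Compound 3 `CCOc1ccc2sc(S(C)(=O)=O)nc2c1S(=O)(=O)NC(CC)CC` has not yet been measured in this assay. The change from compound 2 reads (pentan-3-yl in place of 4-bromophenyl on a sulfonamide nitrogen). It removes the same 4-bromophenyl ring that the step from compound 1 to compound 2 introduced, and puts a branched alkyl group in its place, which resembles the tert-butyl group of compound 1 more than the aromatic ring of compound 2. Within the data shown here, the one step that bears on it therefore points back toward the value of compound 1.

Compound 3 is expected to give roughly 900 nM, within 300 nM to 3000 nM, in this assay. The expected step from compound 2 to compound 3 is thus a 7.6-fold lower number from compound 2 to compound 3 (0.88 log units; beyond the scatter), a lower number, beyond the scatter.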

Compound 3, concentration for 50% growth inhibition: 19500 nM
Estimate against measurement, compound 3: 22-fold (1.34 log units) below, outside the stated range (above it).
By their numbers in this assay, from the lowest: compound 1; then compound 2; then compound 3.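

On the sulfonamide nitrogen, the outcome does not follow a simple division between branched alkyl groups and an aromatic ring: in this assay pentan-3-yl in place of tert-butyl gives a 33-fold higher number from compound 1 to compound 3 (1.51 log units; beyond the scatter) and so costs more than the 4-bromophenyl ring does. Taking out the 4-bromophenyl ring and putting pentan-3-yl in its place does not recover growth inhibition but gives a 2.9-fold higher number from compound 2 to compound 3 (0.46 log units; beyond the scatter) in this assay and places compound 3 last of the three, so two branched alkyl groups here mark the two ends of the series, with the aromatic ring of compound 2 lying between them in value. Nothing available explains why these two branched alkyl groups part so widely at this position and the three compounds alone give no reason for it.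

The compounds shown leave open how the value moves across other alkyl groups on this nitrogen, such as isopropyl, cyclopentyl or cyclohexyl. They also leave open what an unsubstituted phenyl ring would give, and so whether the bromine or the ring itself sets the value of compound 2.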